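A few compounds are considered here, and "the series" means these few. Any claim that something is new, unique, unknown or untested is made for them only; others in the source may bear on it.

Three related compounds have been tested in a functional assay on A549 cells (Homo sapiens) for inhibition, read by MTT assay, with a stated time of 48 h, tested at 10 uM; a higher number here means more inhibition of growth at the concentration tested, a lower number less inhibition of growth. Compound 1 `O=C(/C=C/c1ccc(OCc2cn(Cc3ccc(Br)cc3)nn2)cc1)c1ccc(Br)cc1` gives 27% in this assay. Compound 2 `O=C(/C=C/c1ccc(OCc2cn(Cc3ccccc3F)nn2)cc1)c1ccc(Br)cc1` differs from compound 1 by 2-fluorophenyl in place of 4-bromophenyl on a saturated chain carbon bound to an aromatic nitrogen, and in this assay compound 2 gives 38%, which is a number 11 percentage points higher from compound 1 to compound 2 (beyond the scatter). Compound 3 `O=C(/C=C/c1ccc(OCc2cn(Cc3ccc(Br)cc3)nn2)cc1)c1ccc([N+](=O)[O-])cc1` differs from compound 1 at the other end of the molecule, with nitro in place of bromo on an aromatic carbon, and in this assay compound 3 gives 18%, which is a number 9 percentage points lower from compound 1 to compound 3 (within the scatter). Compound 3 has the lowest of the three numbers, but its gap to compound 1 is within the scatter, so those two cannot be ordered; only compound 2 stands beyond the scatter above it.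

Compound 4 `O=C(/C=C/c1ccc(OCc2cn(Cc3ccccc3F)nn2)cc1)c1ccc([N+](=O)[O-])cc1` has not yet been measured. It relates to compound 3 as compound 2 relates to compound 1: the change is 2-fluorophenyl in place of 4-bromophenyl on a saturated chain carbon bound to an aromatic nitrogen, at the same place, word for word. The two cores on which this change is made differ by nitro in place of bromo on an aromatic carbon.

The step from compound 3 to compound 4 is expected to be a number 11 percentage points higher from compound 3 to compound 4 (beyond the scatter), close in size to the earlier one, because the same change at the same place gave a number 11 percentage points higher from compound 1 to compound 2 (beyond the scatter). That expectation rests on a single earlier instance of the change, so it is held loosely. Starting from the value of compound 3, compound 4 is expected to give 29%, likely between 16% and 42%.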

Compound 4, percent growth inhibition at one concentration: 43%
Compound 4: middle estimate off by 14 percentage points, on the low side; measured number outside the range, above it.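

Going by these compounds alone, replacing 4-bromobenzyl with 2-fluorobenzyl also helps on the nitro core of compound 3, where this assay gives a number 25 percentage points higher from compound 3 to compound 4 (beyond the scatter), so the direction of the change carries over, and its size on the two cores cannot be told apart: the same change on two cores in this assay, a number 11 percentage points higher (beyond the scatter) from compound 1 to compound 2 and a number 25 percentage points higher (beyond the scatter) from compound 3 to compound 4, 14 percentage points apart, within the scatter of two such steps The other change, nitro in place of bromo, now gives a number 5 percentage points higher from compound 2 to compound 4 (within the scatter), and its two readings cannot be told apart either, so neither reading shows that this swap moves the number on its own: the same change on two cores in this assay, a number 9 percentage points lower (within the scatter) from compound 1 to compound 3 and a number 5 percentage points higher (within the scatter) from compound 2 to compound 4, 14 percentage points apart, within the scatter of two such steps This does not show that the step is truly larger on the nitro core, that compound 4 can be ordered against compound 2, or that the change would carry to any core beyond these two, as it rests on only two pairs of compounds read at one concentration.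

The compounds shown leave open whether the gain comes from adding fluorine, from losing bromine, or from where the group sits, a question that a plain benzyl or a chlorobenzyl could help to settle. As far as these compounds go, it is also open how the change would behave with an amine or a carboxylic acid in place of the nitro or bromo group at the other end of the molecule.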